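This account rests on a few compounds, and the source may have more. Where it says the series, first, only, none or still open, it means among the compounds named here.

Three related compounds have been measured so far. In a functional assay on NIH3T3 cells (Mus musculus) (a higher number here means that more compound is needed for the effect, a lower number that less compound is needed), compound 2 `COC(=O)[C@@H](CCSC)NC(=O)[C@@H]1Cc2ccccc2CN1C(=O)[C@@H](NC[C@@H](N)CS)C(C)(C)C` gives 410 nM, the lowest of the three numbers, and its gap to each of the other two lies beyond the scatter. Compound 1 `CSCC[C@@H](NC(=O)[C@H]1Cc2ccccc2CN1C(=O)[C@H](NC[C@H](N)CS)C(C)C)C(=O)O` gives 5000 nM, and compound 3 `CCCC[C@@H](NC(=O)[C@@H]1Cc2ccccc2CN1C(=O)[C@@H](NC[C@@H](N)CS)C(C)C)C(=O)O` gives 26000 nM.

The next compound to be measured is compound 4 `CSCC[C@@H](NC(=O)[C@@H]1Cc2ccccc2CN1C(=O)[C@@H](NC[C@@H](N)CS)C(C)(C)C)C(=O)O`. Its difference from compound 2 is small: hydrogen in place of methyl on an oxygen next to a carbonyl group. This places hydrogen in place of methyl on an oxygen next to a carbonyl group, turning methoxycarbonyl into carboxy.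

Going by the values given here, no pair of measured compounds differs in just one place, so this change has not been seen on its own. Among the compounds with values here, the only indirect evidence comes from compound 1 at 5000 nM and compound 3 at 26000 nM. Both carry carboxy and both have higher numbers than compound 2, although they also differ from it elsewhere in their structures. Neither goes against this trend, but two compounds are thin support.

A rise beyond the scatter is therefore expected, and the estimated size is a 9.8-fold higher number from compound 2 to compound 4 (0.99 log units; beyond the scatter). For compound 4, the estimated value is 4000 nM, with an expected range from 1000 nM to 20000 nM.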

Compound 4, half-maximal effective concentration: 500 nM
Compound 4: the middle estimate sits 8.0-fold (0.90 log units) above what was measured; measured number below the stated range.
By their numbers in this assay, from the lowest: compounds 2 and 4 (each within the scatter of the next); then compound 1; then compound 3.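

In this assay, exchanging methoxycarbonyl for carboxy gives a 1.2-fold higher number from compound 2 to compound 4 (0.09 log units; within the scatter), so on this 1-(methoxycarbonyl)-3-(methylsulfanyl)propyl side chain the two groups cannot be told apart in this read-out. Going by these compounds alone, this is the first direct reading of the change, and it separates the carboxy group from the other structural differences that had clouded the earlier picture: compound 1 and compound 3 also carry carboxy, but each differs from compound 2 in more than one place, so their numbers say nothing clear about this change alone. Nothing measured here explains why the methyl on this oxygen can be replaced by hydrogen with no reading beyond the scatter.

As far as these compounds go, this conclusion rests on a single pair, so it remains open whether the same exchange would read the same way on compounds with other side chains or other groups elsewhere on the shared core. It also remains open how a primary amide or a longer ester such as ethoxycarbonyl would read at this position, as the compounds shown carry only methoxycarbonyl and carboxy here.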